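The source may report more compounds than this note shows. Statements on the series, on what has been measured and on what is new or still open speak of the compounds shown alone.

Measured in a functional assay on 4T1 cells (Mus musculus) for cytotoxicity, read by MTT assay, with a stated time of 24 h; a lower number here means a stronger inhibitor, a higher number a weaker inhibitor:
- compound 1 `Cc1ccc(/C=C2\CN(C(=S)SCc3cn(Cc4ccc(F)cc4)nn3)C/C(=C\c3ccc(C)cc3)C2=O)cc1`: 29300 nM
- compound 2 `Cc1ccc(/C=C2\CN(C(=S)SCc3cn(Cc4cccc(Cl)c4)nn3)C/C(=C\c3ccc(C)cc3)C2=O)cc1`: 53400 nM
- compound 3 `Cc1ccc(/C=C2\CN(C(=S)SCc3cn(Cc4ccccc4F)nn3)C/C(=C\c3ccc(C)cc3)C2=O)cc1`: 28400 nM

In this assay, compound 3 gives 28400 nM, which lies within the scatter of both other values. Compound 4 `Cc1ccc(/C=C2\CN(C(=S)SCc3cn(Cc4ccccc4Cl)nn3)C/C(=C\c3ccc(C)cc3)C2=O)cc1` differs from it by chloro in place of fluoro on an aromatic carbon, ortho to a large group. For the measured compounds named here, three measured steps bear on this. The closest is a 1.9-fold lower number from compound 2 to compound 3 (0.27 log units; within the scatter), where chloro and fluoro also differ in where they sit. The others are a 1.8-fold higher number from compound 1 to compound 2 (0.26 log units; within the scatter) and a 1.0-fold lower number from compound 1 to compound 3 (0.01 log units; within the scatter). None exceeds the scatter, so no step beyond it is expected in this assay. The expected change is a 1.2-fold higher number from compound 3 to compound 4 (0.09 log units; within the scatter). For compound 4 the estimated value is 35000 nM, with an expected range of 18000 nM to 65000 nM.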

Compound 4, half-maximal inhibitory concentration: 49300 nM
For compound 4 the middle estimate is 1.4-fold (0.15 log units) below the measured one; the range from low to high includes it.
By their numbers in this assay, from the lowest: compounds 3, 1, 4 and 2 (each within the scatter of the next).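

In this assay, for the compounds shown here, the change of fluoro to chloro ortho to a large group gives a 1.7-fold higher number from compound 3 to compound 4 (0.24 log units; within the scatter) and is the first step here that alters the halogen while its place stays fixed. With chloro kept, 2-chlorophenyl in place of 3-chlorophenyl gives a 1.1-fold lower number from compound 2 to compound 4 (0.03 log units; within the scatter) and 2-chlorophenyl in place of 4-fluorophenyl gives a 1.7-fold higher number from compound 1 to compound 4 (0.23 log units; within the scatter) so this position has shown no step beyond the scatter among these halogens. Nothing available explains these small steps. On these data alone, whether an amine, a carboxylic acid or a methoxy group on this ring would exceed the scatter remains open.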